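This account rests on a few compounds, and the source may have more. Where it says the series, first, only, none or still open, it means among the compounds named here.

Compound 1, `CC1=C(SCCCO)C(=O)c2ccccc2C1=O`: in a functional assay on NPC-TW-039 cells (Homo sapiens) for inhibition, with NPC-TW-039 (Mus musculus) as the target (on this read-out higher numbers stand for weaker inhibition and lower numbers for stronger inhibition), compound 1 gives > 10000 nM, which is a limit of the assay and not a number.
Compound 2, `CC1=C(SCCCCO)C(=O)c2ccccc2C1=O`: compound 2 gives > 10000 nM, likewise a limit.
Compound 3, `CC1=C(SCCCCCCO)C(=O)c2ccccc2C1=O`: compound 3 gives > 10000 nM, again a limit.

All three measured compounds share the same core and differ only in the hydroxy-bearing chain attached to the sulfur. None of them reaches a readable number: the limit of > 10000 nM in this assay, at which 3 of the 3 values shown sit. Compound 3 therefore stands at the limit, neither above nor below its two neighbours in any way that can be stated. The three steps among the measured compounds, a step that the two limits leave unreadable from compound 1 to compound 2, a step that the two limits leave unreadable from compound 1 to compound 3 and a step that the two limits leave unreadable from compound 2 to compound 3, are all unreadable for the same reason, so they give no direction and no size to lean on.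

Compound 4, `CC1=C(SC(C)C(C)O)C(=O)c2ccccc2C1=O`, carries a shorter, branched chain instead: 2-hydroxy-1-methylpropyl in place of 6-hydroxyhexyl on a sulfur. Among the compounds with values here, no measured step speaks to a branch of this kind, and no measured step shows any movement at all, so there is no basis to expect a change beyond the scatter. The estimate for compound 4 is 10000 nM, with a range from 3000 nM to 30000 nM, meaning an expected step of a number no higher from compound 3 to compound 4 (the limit leaves the size open), and most likely the assay will again report only a limit.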

Compound 4, half-maximal inhibitory concentration: > 10000 nM
Compound 4 ended at the assay's limit (the forecaster's own chance of this, stated with the estimate: 75%); the middle value sits exactly at the limit.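

Compound 4 joins compound 1, compound 2 and compound 3 at a limit rather than a number, so none of the steps to compound 4 can be read: the limit of > 10000 nM in this assay, at which 4 of the 4 values shown sit.

The compounds shown leave open whether any chain on the sulfur of the shared core gives a readable value, and how these four compounds rank.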